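The source may report more compounds than this note shows. Statements on the series, on what has been measured and on what is new or still open speak of the compounds shown alone.

Working notes on the series, read out in an ADME assay on BJ cells (Homo sapiens) for cytotoxicity, with a stated time of 72 h; on this read-out higher numbers stand for an effect only at larger amounts of compound and lower numbers for an effect already at smaller amounts:

compound 1 `COc1cccc(-c2nc3c(c(C)nn3-c3ccccc3)c(-c3ccccc3O)c2C#N)c1`: > 23000 nM (a limit)
compound 2 `CCc1ccc(-c2nc3c(c(C)nn3-c3ccccc3)c(-c3ccccc3C(=O)O)c2C#N)cc1`: > 20000 nM (a limit)
compound 3 `C#Cc1ccccc1-c1c(C#N)c(-c2ccc(CC)cc2)nc2c1c(C)nn2-c1ccccc1`: > 20000 nM (a limit)

Compound 1 gives only a limit and no number: > 23000 nM. Compound 2 and compound 3 likewise give only limits, and the two share (the limit of > 20000 nM in this assay, at which 2 of the 3 values shown sit).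

Next in line is compound 4 `CCCc1ccc(-c2nc3c(c(C)nn3-c3ccccc3)c(-c3ccccc3O)c2C#N)cc1`, which keeps the core of compound 1 and its 2-hydroxyphenyl group. The change is 4-propylphenyl in place of 3-methoxyphenyl on an aromatic carbon, on the aromatic carbon next to the ring nitrogen and ortho to the cyano group.

Among the measured compounds shown here, only one measured step exists: a step that the two limits leave unreadable from compound 2 to compound 3. It gives no size, and it concerns the carboxy group rather than the place changed here, so it bears on this change only weakly. What remains is that all three measured compounds end in limits, whichever groups they carry.

With compound 1 at > 23000 nM, a limit, no step beyond the scatter is expected in this assay, and no direction can be argued. The expected change is an at least 1.1-fold lower number from compound 1 to compound 4 (0.06 log units; that floor lies within the scatter). A limit is again the likeliest report, though a number near the top of the tested range remains possible. For compound 4 the estimated value is 20000 nM, with an expected range from 8000 nM to 40000 nM.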

Compound 4, half-maximal effective concentration: 22500 nM
For compound 4 the middle estimate is 1.1-fold (0.05 log units) below the measured one; the measured number falls inside the stated range.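

In this assay compound 4 is the only compound shown that gives a number and not a limit, 22500 nM, so with 4-propylphenyl on the aromatic carbon next to the ring nitrogen and ortho to the cyano group, an effect can be read within the tested range. Setting 4-propylphenyl in place of 3-methoxyphenyl at this position, with the 2-hydroxyphenyl group kept, gives an at least 1.0-fold lower number from compound 1 to compound 4 (0.00 log units; that floor lies within the scatter), and the change therefore shows no step beyond the scatter. Compound 1 gives only a limit, and the true size of the step stays unreadable because of that limit: the limit of > 23000 nM in this assay, at which 1 of the 4 values shown sits.

From the compounds shown here alone, whether the number for compound 4 goes with the propyl chain, with the substituent's place on the phenyl ring or with the loss of the methoxy group stays open, as this one change alters all three at once. Equally open, going by these compounds, is how this position would read in this assay with an amine or with a chain longer than propyl, and whether any group here can bring the number clearly below the top of the tested range.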